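This account rests on a few compounds, and the source may have more. Where it says the series, first, only, none or still open, it means among the compounds named here.

Compound 1 `O=C1Nc2ccc(Cl)cc2C1(c1c(-c2ccccc2)[nH]c2ccccc12)c1c(-c2ccccc2)[nH]c2ccccc12`: in a functional assay on MDA-MB-231 cells (Homo sapiens) for cytotoxicity, read by MTT assay, with a stated time of 48 h (on this read-out lower numbers stand for stronger inhibition and higher numbers for weaker inhibition), compound 1 gives > 100000 nM, which is a limit of the assay and not a number.
Compound 2 `O=C1Nc2ccccc2C1(c1c[nH]c2ccc([N+](=O)[O-])cc12)c1c[nH]c2ccc([N+](=O)[O-])cc12`: compound 2 gives 9980 nM.
Compound 3 `COC(=O)c1ccc2[nH]cc(C3(c4c[nH]c5ccc(C(=O)OC)cc45)C(=O)Nc4ccc(Cl)cc43)c2c1`: compound 3 gives 10000 nM.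

Compound 1 therefore sits at the limit of > 100000 nM in this assay, at which 1 of the 3 values shown sits, with no number of its own, while compound 2 and compound 3 return values that lie within the scatter of each other. Going by the values given here, no pair of the measured compounds differs in a single place, so no measured step is available.

Compound 4 `O=C1Nc2ccccc2C1(c1c(-c2ccccc2)[nH]c2ccccc12)c1c(-c2ccccc2)[nH]c2ccccc12` differs from compound 1 by hydrogen in place of chloro on an aromatic carbon. In this assay the step expected is a step that the limit leaves unreadable from compound 1 to compound 4, that is, none beyond the scatter, with the limit likely to be reported again. Compound 4 is accordingly estimated at 150000 nM, in the range 30000 nM to 600000 nM.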

Compound 4, half-maximal inhibitory concentration: > 100000 nM
Compound 4: no number, only a limit; the forecaster's own chance of this, stated with the estimate: 70%; the middle value does not contradict the limit.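

Compound 1 and compound 4 both return only a limit of the assay in this assay, so no step between them can be read: the limit of > 100000 nM in this assay, at which 2 of the 4 values shown sit.

The compounds shown leave open what hydrogen in place of chloro does to cytotoxicity.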